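Pyrazole to methylpyrrole on the shared core: expected effect

The compounds below may be only part of what the source reports. "The series", "measured", "known", "first", "only" and "open" are said of these compounds alone.

Compound 3 `c1ccc(-c2cn[nH]c2)c(NCC2=NCCN2)c1`: 20 nM
Compound 1 `CCn1cc(-c2ccccc2NCC2=NCCN2)cn1`: < 100000 nM
Compound 2 `CCn1nccc1-c1ccccc1NCC1=NCCN1`: < 100000 nM

Compound 3 is the only one of the three with a number in an in vitro functional assay on cells (Fibroblast) for agonist activity at Alpha-1D adrenergic receptor (Homo sapiens); on this read-out lower numbers stand for an effect already at smaller amounts and higher numbers for an effect only at larger amounts of compound; compound 3 gives 20 nM. For compound 1 the read-out is a limit of the assay, < 100000 nM. For compound 2 likewise only a limit is known, < 100000 nM. For the measured compounds named here, the one single-point step, a step that the limit leaves unreadable from compound 1 to compound 3, is therefore unreadable in size because of the limit of < 100000 nM in this assay, at which 2 of the 3 values shown sit.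

Compound 4 `Cn1cccc1-c1ccccc1NCC1=NCCN1` differs from compound 3 in one place: 1-methyl-1H-pyrrol-2-yl in place of 1H-pyrazol-4-yl on an aromatic carbon. No measured step bears directly on this change; the only step shown is unreadable. The group entering carries no hydrogen-bond donor, where the leaving group carried one. Compound 4 is expected to be weaker, by about a 15-fold higher number from compound 3 to compound 4 (1.18 log units; beyond the scatter), and is estimated at 300 nM in this assay, within 30 nM to 5000 nM.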

Compound 4, half-maximal effective concentration: 251 nM
Estimate against measurement, compound 4: 1.2-fold (0.08 log units) above, within the range that was stated.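

For the compounds shown here, on this aromatic carbon, 1-methyl-1H-pyrrol-2-yl in place of 1H-pyrazol-4-yl gives the first readable step in this assay, a 13-fold higher number from compound 3 to compound 4 (1.10 log units; beyond the scatter). Compound 4 still gives a number although its entering group has 0 hydrogen-bond donors, so a donor on this group is not needed for a measurable effect, though the step is large. The step from compound 1 to compound 3 cannot be read: the limit of < 100000 nM in this assay, at which 2 of the 4 values shown sit.

On these data alone, whether the step follows the lost donor, the added methyl or the change of ring stays open. An unsubstituted pyrrole, an amine or a carboxylic acid in this place would help to separate these.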